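A few compounds are considered here, and "the series" means these few. Any claim that something is new, unique, unknown or untested is made for them only; others in the source may bear on it.

Working notes on the series. Compound 1 `O=C(Nc1cccc(-n2cc(-c3ccncc3)c(-c3cc(O)cc(Cl)c3)n2)c1)Nc1ccc(Cl)c(Cl)c1` in a functional assay on HCC 2998 cells (Homo sapiens) for inhibition, read by sulforhodamine B assay, with a stated time of 48 h, tested at 0.01 uM (a higher number here means a weaker effect of the compound at the concentration tested, a lower number a stronger effect), gives 104%. Compound 2 `COc1cc(Cl)cc(-c2nn(-c3cccc(NC(=O)Nc4cc(C(F)(F)F)cc(C(F)(F)F)c4)c3)cc2-c2ccncc2)c1` in this assay gives 95%. Within the data shown here, of the two numbers so far, compound 2 sits at the low end, with compound 1 the nearest number, the gap between them being within the usual scatter, so the two cannot be told apart on these data. Both readings indicate essentially no inhibition at the concentration tested.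

Compound 3 `COc1cc(Cl)cc(-c2nn(-c3cccc(NC(=O)Nc4cccc(C(F)(F)F)c4)c3)cc2-c2ccncc2)c1` is the next member to be measured in this assay. Its structure differs from compound 2 as follows: hydrogen in place of trifluoromethyl on an aromatic carbon. Among the measured compounds shown here, no step between two measured compounds of this kind is available, so there is no precedent for this change. Given that compound 2 gives 95% and compound 1 gives 104%, neither showing an effect, the step from compound 2 to compound 3 in this assay is expected to be none beyond the scatter, estimated as a number 3 percentage points higher from compound 2 to compound 3 (within the scatter). Compound 3 is therefore expected to give 98% in this assay, with a range of 85% to 110%.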

Compound 3, a percentage reported as activity, at one concentration (the size of the read-out at that concentration, not a potency): 98%
For compound 3 middle estimate and measured number coincide at the digits printed; low and high end bracket the measured number.
By their numbers in this assay, from the lowest: compounds 2, 3 and 1 (each within the scatter of the next).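

Hydrogen in place of trifluoromethyl on an aromatic carbon gives a number 3 percentage points higher from compound 2 to compound 3 (within the scatter) in this assay, the first step in the series that changes one place only. At this position, meta to a large group, removing a trifluoromethyl group of 4 heavy atoms therefore produces no change that can be told from the scatter, and compound 3 shows essentially no inhibition at the concentration tested, as compound 2 does. No data at hand bear on the reason for this result.

Since neither compound of the pair shows an effect here, the step cannot tell whether this position matters for inhibition at all, or whether the same change would read differently at a higher concentration. Also open, from the compounds shown here alone, is whether a different group on this aromatic carbon, such as an amine, a nitrile or a carboxylic acid, would move the read-out beyond the scatter in this assay.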